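Aryl piperazine succinimide amides in the seizure model

The compounds below may be only part of what the source reports. "The series", "measured", "known", "first", "only" and "open" are said of these compounds alone.

Measured in a functional assay on the whole organism (strain Swiss) with Mus musculus as the target, in the maximal electroshock model, with a stated time of 0.25 h, at a dose of 300 mg/kg by the intraperitoneal route; a higher number here means a stronger effect of the compound at the dose given, a lower number a weaker effect:
compound 1, `CCC(C(=O)N1CCN(c2ccccc2F)CC1)N1C(=O)CCC1=O`: 100%
compound 2, `CCC(C(=O)N1CCN(c2ccccc2)CC1)N1C(=O)CCC1=O`: 75%
compound 3, `CCC(C(=O)N1CCN(c2cccc(C)c2)CC1)N1C(=O)CCC1=O`: 100%

Compound 3 stands level with compound 1 at the digits read, the two together the highest of the three numbers; against compound 2 the step is a number 25 percentage points higher from compound 2 to compound 3 (beyond the scatter). The next step leads to compound 4, `CCC(C(=O)N1CCN(c2ccccc2Cl)CC1)N1C(=O)CCC1=O`, the change being (2-chlorophenyl in place of 3-methylphenyl on an amine nitrogen in a ring). Within the data shown here, no measured pair swaps a 3-methylphenyl for a 2-chlorophenyl directly. Among the measured compounds shown here, the steps that bear on it are a number 25 percentage points lower from compound 1 to compound 2 (beyond the scatter) and no change at the digits printed from compound 1 to compound 3 (within the scatter), showing that a fluoro-bearing phenyl and a methyl-bearing phenyl on the ring nitrogen sit at the same high level, while the bare phenyl of compound 2 falls short. A chloro-bearing phenyl, as in compound 4, is expected to hold that level, a number 5 percentage points lower from compound 3 to compound 4 (within the scatter). The estimate for compound 4 is 95%, ranging from 75% to 100%.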

Compound 4, a percentage reported as activity, at one dose (the size of the read-out at that dose, not a potency): 50%
Compound 4: middle estimate off by 45 percentage points, on the high side, and the stated range ends above it.
By their numbers in this assay, from the lowest: compound 4; then compound 2; then compounds 1 and 3 (each within the scatter of the next).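

Chloro in place of fluoro gives a number 50 percentage points lower from compound 1 to compound 4 (beyond the scatter) in this assay, so the two halogens do not sit at the same level on this phenyl. Substitution here can also lower the read-out: chloro in place of hydrogen gives a number 25 percentage points lower from compound 2 to compound 4 (beyond the scatter), while 2-chlorophenyl in place of 3-methylphenyl gives a number 50 percentage points lower from compound 3 to compound 4 (beyond the scatter), the reverse of the rise seen with methyl. No measurement bearing on the cause of this drop is available.

As far as these compounds go, whether a bromo, methoxy or trifluoromethyl group on the phenyl would follow chloro or fluoro remains open. How the chloro and fluoro groups would compare elsewhere on the phenyl is also unresolved.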